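Replacing pyridin-3-yl in compound 2: working notes

The compounds below may be only part of what the source reports. "The series", "measured", "known", "first", "only" and "open" are said of these compounds alone.

For the measured compounds named here, compound 2 `Cc1c(OCc2cccnc2)ccc2c(N3CCNCC3)cc(=O)oc12` gives 980 nM in a functional assay on a cell-free system (plasma, Homo sapiens) for inhibition, with Plasma (Rattus norvegicus) as the target (a higher number here means a weaker inhibitor, a lower number a stronger inhibitor), the lowest number of the three measured so far. Compound 3 `COCOc1ccc2c(N3CCNCC3)cc(=O)oc2c1C` stands at 2300 nM, and compound 1 `O=c1cc(N2CCNCC2)c2c(OCc3ccccc3)cccc2o1` at 187000 nM.

Compound 4 `CSCCOc1ccc2c(N3CCNCC3)cc(=O)oc2c1C` has not yet been measured. Its difference from compound 2 is (methylsulfanyl)methyl in place of pyridin-3-yl on a saturated chain carbon bound to an oxygen on an aromatic ring. In words, (methylsulfanyl)methyl stands in place of pyridin-3-yl on a saturated chain carbon bound to an oxygen on an aromatic ring, which also reads as (pyridin-3-yl)methoxy to 2-(methylsulfanyl)ethoxy.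

Going by the values given here, only one measured step bears on this, methoxy in place of pyridin-3-yl at the same place. It was modest but beyond the scatter: a 2.3-fold higher number from compound 2 to compound 3 (0.37 log units; beyond the scatter). Among the compounds with values here, no measured compound carries (methylsulfanyl)methyl, so this single step is the only guide. A step of similar modest size towards a higher number is therefore expected in this assay. The estimated step is a 1.9-fold higher number from compound 2 to compound 4 (0.29 log units; within the scatter). The estimate for compound 4 is 1900 nM, with an expected range of 700 nM to 5500 nM.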

Compound 4, half-maximal inhibitory concentration: 1500 nM
Compound 4: the middle estimate sits 1.3-fold (0.10 log units) above what was measured; measured number inside the range.
By their numbers in this assay, from the lowest: compounds 2, 4 and 3 (each within the scatter of the next, the first and the last beyond it); then compound 1.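

In this assay, an open chain can stand in place of the aromatic ring at this position: (methylsulfanyl)methyl replaces pyridin-3-yl, going from 6 heavy atoms to 3, with a 1.5-fold higher number from compound 2 to compound 4 (0.18 log units; within the scatter) as the result. The earlier step to methoxy did not show that a sulfur-bearing chain is accommodated here, and a 1.5-fold lower number from compound 3 to compound 4 (0.19 log units; within the scatter) leaves (methylsulfanyl)methyl and methoxy unseparated. No supporting measurement accounts for either step.

Across pyridin-3-yl, methoxy and (methylsulfanyl)methyl, this position has so far shown only small steps, so its sensitivity to larger changes remains unknown. As far as these compounds go, it remains open whether a dimethylamino group, a carboxylic acid or a longer alkyl chain on the same saturated chain carbon would keep the number in this range.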